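Adding a Methyl to the Hydroxyethyl Chain

The source may report more compounds than this note shows. Statements on the series, on what has been measured and on what is new or still open speak of the compounds shown alone.

Compound 3 `O=C(Nc1ccc(Oc2cc(NCCO)ncn2)cc1)Nc1cccc(C(F)(F)F)c1` holds the lowest of the three numbers measured in an assay on isolated protein for inhibition of serine/threonine-protein kinase TNNI3K (Homo sapiens) (on this read-out higher numbers stand for weaker inhibition and lower numbers for stronger inhibition), compound 3 giving 32 nM. Its nearest neighbour is compound 1 `CC(C)CNc1cc(Oc2ccc(NC(=O)Nc3cccc(C(F)(F)F)c3)cc2)ncn1`, which in this assay gives 50 nM; the step of a 1.6-fold lower number from compound 1 to compound 3 (0.19 log units; within the scatter) lies within the scatter, so no order between these two can be claimed. The furthest is compound 2 `CN(C)c1cc(Oc2ccc(NC(=O)Nc3cccc(C(F)(F)F)c3)cc2)ncn1`, which in this assay gives 2500 nM; the step of a 78-fold lower number from compound 2 to compound 3 (1.89 log units; beyond the scatter) is large. Compound 4 `C[C@H](O)CNc1cc(Oc2ccc(NC(=O)Nc3cccc(C(F)(F)F)c3)cc2)ncn1` is not yet measured; it differs from compound 3 by methyl in place of hydrogen on a saturated chain carbon bound to an oxygen on a saturated carbon and a saturated chain carbon. Of the measured steps, the one that bears most directly on this change is a 1.6-fold lower number from compound 1 to compound 3 (0.19 log units; within the scatter), where the chain carbon bound to the ring nitrogen carried either hydroxymethyl or isopropyl without a difference beyond the scatter. The large steps of a 50-fold higher number from compound 1 to compound 2 (1.70 log units; beyond the scatter) and a 78-fold lower number from compound 2 to compound 3 (1.89 log units; beyond the scatter) both concern dimethylamino on the aromatic carbon, a change of a different kind, and do not speak to a methyl on the chain. For compound 4 in this assay a step of no more than the scatter is therefore expected, in either direction, namely a 1.1-fold lower number from compound 3 to compound 4 (0.03 log units; within the scatter). Compound 4 is expected to give 30 nM, within the range 12 nM to 80 nM.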

Compound 4, half-maximal inhibitory concentration: 32 nM
The estimate for compound 4 lay 1.1-fold (0.03 log units) below the measured number; low and high end bracket the measured number.
By their numbers in this assay, from the lowest: compounds 3, 4 and 1 (each within the scatter of the next); then compound 2.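

In this assay, for the compounds shown here, the methyl on the saturated chain carbon bound to an oxygen leaves the read-out unmoved (no change at the digits printed from compound 3 to compound 4 (within the scatter)), so (2-hydroxypropyl)amino and (2-hydroxyethyl)amino cannot be told apart here, something the earlier compounds, none of which carried a substituent on this carbon, could not show. The other two steps extend the earlier picture to the new side chain: the exchange of isopropyl for 1-hydroxyethyl on the saturated chain carbon bound to a nitrogen stays within the scatter (a 1.6-fold lower number from compound 1 to compound 4 (0.19 log units; within the scatter)), while the exchange of dimethylamino for (2-hydroxypropyl)amino is as large as the one seen for (2-hydroxyethyl)amino (a 78-fold lower number from compound 2 to compound 4 (1.89 log units; beyond the scatter)). Nothing shown explains why the methyl makes no difference, or any of these steps.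

Compound 4 carries a single hand at the new chain carbon, so the mirror-image 2-hydroxypropyl group remains an open case, as does a second methyl on that same carbon. Also open, from the compounds shown here alone, is how far this insensitivity reaches: a longer chain such as 3-hydroxypropyl, or an amine or a carboxylic acid in place of the hydroxy group, could read differently.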